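Urea and amide analogues: acetamido to benzamido

The source may report more compounds than this note shows. Statements on the series, on what has been measured and on what is new or still open speak of the compounds shown alone.

Measured values in a functional assay on A375P cells (Homo sapiens) for antiproliferative activity; a higher number here means a weaker inhibitor, a lower number a stronger inhibitor:
compound 1 `CC(=O)Nc1cc(NC(=O)Nc2ccc(C)c(C)c2)ccc1C` — compound 1 gives > 30000 nM, a limit of the assay.
compound 2 `Cc1ccc(NC(=O)Nc2ccc(C)c(NC(=O)c3ccccc3)c2)cc1C` — compound 2 gives > 30000 nM, also a limit.
compound 3 `CC(=O)Nc1cc(NC(=O)c2ccc3c(c2)OCCO3)ccc1C` — compound 3 gives 12900 nM.

Compound 1 and compound 2 differ by phenyl in place of methyl on a carbonyl carbon; the step that the two limits leave unreadable from compound 1 to compound 2, since both values sit at the limit of > 30000 nM in this assay, at which 2 of the 3 values shown sit. For the measured compounds named here, compound 3 is the only compound with a number rather than a limit. How the core of compound 3 differs from that of compound 1 is not broken down here. Compound 4 `Cc1ccc(NC(=O)c2ccc3c(c2)OCCO3)cc1NC(=O)c1ccccc1`, not yet measured, differs from compound 3 by phenyl in place of methyl on a carbonyl carbon, the same change as that between compound 1 and compound 2, at the same place. The earlier step gives no readable size, so the expectation for compound 4 rests on compound 3 giving 12900 nM. Compound 4 is expected to give 15000 nM, with a range estimated from 4000 nM to 40000 nM. The expected step of a 1.2-fold higher number from compound 3 to compound 4 (0.07 log units; within the scatter) is small.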

Compound 4, half-maximal inhibitory concentration: > 30000 nM
Compound 4: only a limit was reported; the forecaster's own chance of this, stated with the estimate: 35%; middle value at least 2.0-fold (0.30 log units) from the limit.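

In this assay the change from acetamido to benzamido on the core of compound 3 gives an at least 2.3-fold higher number from compound 3 to compound 4 (0.36 log units; beyond the scatter), so on this core the phenyl on the carbonyl carbon goes with weaker activity. As far as these compounds go, compound 4 gives > 30000 nM, which is a limit, so the full size of that step stays unknown. The step from compound 1 to compound 2 cannot be read, so this one pair shows no carry-over between cores, and most of the series gives no number: the limit of > 30000 nM in this assay, at which 3 of the 4 values shown sit.

Open, from the compounds shown here alone, is whether an amine or a carboxylic acid in place of the phenyl on this carbonyl carbon would give a number on the core of compound 3. Also open, going by these compounds, is whether a longer chain there would bring the core of compound 1 off the limit.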